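This account rests on a few compounds, and the source may have more. Where it says the series, first, only, none or still open, it means among the compounds named here.

Measured in an ADME assay on CCRF-CEM cells (Homo sapiens) for cytotoxicity, read by MTT assay, with a stated time of 72 h; on this read-out higher numbers stand for lower toxicity in this test and lower numbers for higher toxicity in this test:
- Compound 1 `CC(C)=CCOc1c(CC=C(C)C)c(O)nc2ccccc12`: 71200 nM
- Compound 2 `CCCCOc1c(CCCC)c(O)nc2ccccc12`: 192000 nM
- Compound 3 `CC(C)=CCOc1cc(O)nc2ccccc12`: 77400 nM

Compound 3 sits level with compound 1, and the number for compound 2 is higher than either. Compound 4 `C#CCOc1cc(O)nc2ccccc12` keeps the core of compound 3 and changes one chain: ethynyl in place of 2-methylprop-1-en-1-yl on a saturated chain carbon bound to an oxygen on an aromatic ring. In other words, 3-methylbut-2-en-1-yl gives way to propargyl on the oxygen. Among the measured compounds shown here, the one measured single change, hydrogen in place of 3-methylbut-2-en-1-yl on an aromatic carbon, gave a 1.1-fold higher number from compound 1 to compound 3 (0.04 log units; within the scatter). For the measured compounds named here, it lies at a different place, so it is only a weak guide, and no measured step changes the chain on oxygen alone. Only a small move is expected, with nothing beyond the scatter: a 1.2-fold higher number from compound 3 to compound 4 (0.07 log units; within the scatter). The estimate for compound 4 is 90000 nM, with an expected range from 40000 nM to 190000 nM.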

Compound 4, half-maximal cytotoxic concentration: 103000 nM
The estimate for compound 4 lay 1.1-fold (0.06 log units) below the measured number, and the stated range covers the measured number.
By their numbers in this assay, from the lowest: compounds 1, 3, 4 and 2 (each within the scatter of the next, the first and the last beyond it).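

Among the compounds shown here, replacing 3-methylbut-2-en-1-yl with propargyl on the oxygen gives the first measured change to this chain in this assay (a 1.3-fold higher number from compound 3 to compound 4 (0.12 log units; within the scatter)). At this place on the shared core, the double bond of the chain can give way to a triple bond, in a chain with fewer carbons, without a change beyond the scatter. Nothing available explains why this step is so small.

From the compounds shown here alone, whether an amine, a carboxylic acid or a longer chain on this oxygen would shift the number beyond the scatter remains open. So does whether propargyl would behave the same way in the presence of a second chain on the aromatic carbon, as in compound 1.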